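The source may report more compounds than this note shows. Statements on the series, on what has been measured and on what is new or still open speak of the compounds shown alone.

Among the compounds with values here, compound 2 `Oc1ccc(-c2cc(-c3cccnc3)cc(-c3ccccc3O)n2)cc1` stands lowest of the two numbers known in an assay on isolated protein for inhibition of DNA topoisomerase 1 (Homo sapiens), with a stated time of 30 min, tested at 100 uM (on this read-out higher numbers stand for a stronger effect at the one concentration tested and lower numbers for a weaker effect), where compound 2 gives 1.5%. Its nearest neighbour is compound 1 `Oc1ccc(-c2cc(-c3ccco3)cc(-c3cccc(O)c3)n2)cc1`, which in this assay gives 100%, a gap beyond the scatter. Compound 3 `Oc1ccc(-c2cc(-c3cccnc3)cc(-c3cccc(O)c3)n2)cc1` is not yet measured; its structure differs from compound 2 as follows: 3-hydroxyphenyl in place of 2-hydroxyphenyl on an aromatic carbon. Within the data shown here, no measured pair isolates this change, so the expected step is uncertain in size. Because compound 1 carries the same 3-hydroxyphenyl group and gives 100%, an upward step is expected from compound 2 to compound 3 of a number 43.5 percentage points higher from compound 2 to compound 3 (beyond the scatter), with compound 3 estimated at 45%, ranging from 5% to 95%.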

Compound 3, a percentage reported as inhibition, at one concentration (the size of the read-out at that concentration, not a potency): 5.9%
For compound 3 the middle estimate is 39.1 percentage points above the measured one; the measured number falls inside the stated range.
By their numbers in this assay, from the lowest: compounds 2 and 3 (each within the scatter of the next); then compound 1.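

In this assay, placing 3-hydroxyphenyl instead of 2-hydroxyphenyl next to the ring nitrogen gives a number 4.4 percentage points higher from compound 2 to compound 3 (within the scatter), so with pyridin-3-yl in place this change shows no real effect. The 3-hydroxyphenyl group alone therefore does not carry the high read-out of compound 1: pyridin-3-yl in place of furan-2-yl gives a number 94.1 percentage points lower from compound 1 to compound 3 (beyond the scatter). Nothing available explains either step. Still open, from the compounds shown here alone, is whether the hydroxyl position matters with furan-2-yl present, and how an aminophenyl group next to the ring nitrogen would read.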